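Purine ribosides with an aryl sulfide chain

The source may hold more compounds than are shown below. What is called first, only, known or untested is meant among the compounds shown, and "the series" means these compounds.

Two measured compounds define this small set. Compound 1 `OC[C@H]1O[C@@H](n2cnc3c(Sc4ccccc4)ncnc32)[C@H](O)[C@@H]1O` carries a phenylsulfanyl group on the shared core. In an assay on isolated protein for binding affinity to Equilibrative nucleoside transporter 1 (Homo sapiens) (on this read-out higher numbers stand for weaker inhibition and lower numbers for stronger inhibition), compound 1 gives 91200 nM, the lowest of the two numbers recorded. Compound 2 `CC(=O)c1ccccc1Sc1nc(N)nc2c1ncn2[C@@H]1O[C@H](CO)[C@@H](O)[C@H]1O` differs in several places at once, and in this assay compound 2 gives 447000 nM; the gap between the two values lies beyond the usual scatter, but since the structures differ in more than one place, nothing about any single change can be read from it.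

Compound 3 `OC[C@H]1O[C@@H](n2cnc3c(CSc4cccc(I)c4)ncnc32)[C@H](O)[C@@H]1O` has not yet been measured. Relative to compound 1 the change is a group of 9 heavy atoms (7 carbon, 1 sulfur, 1 iodine; one six-membered aromatic ring of carbon only) in place of a group of 7 heavy atoms (6 carbon, 1 sulfur; one six-membered aromatic ring of carbon only), on an aromatic carbon. The phenylsulfanyl group leaves, and a longer group that still holds a sulfur and an aromatic ring of carbon only, now bearing iodine, takes its place.

For the measured compounds named here, no measured pair in this set isolates such a change, so the expectation rests on compound 1 alone. The step from compound 1 to compound 3 is estimated to lower the number, a 9.1-fold lower number from compound 1 to compound 3 (0.96 log units; beyond the scatter), with wide uncertainty. For compound 3 in this assay the estimate is 10000 nM, within a range from 1000 nM to 60000 nM.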

Compound 3, half-maximal inhibitory concentration: 245 nM
Beside the measured number, compound 3's estimate is 41-fold (1.61 log units) above it; measured number below the stated range.
By their numbers in this assay, from the lowest: compound 3; then compound 1; then compound 2.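

In this assay, replacing phenylsulfanyl with the longer, iodine-bearing group gives a 370-fold lower number from compound 1 to compound 3 (2.57 log units; beyond the scatter), so the group on this aromatic carbon of the shared core has a very large bearing on the number. Compound 1 and compound 2 differ in several places and could not show this, whereas compound 1 and compound 3 differ in one place only, and the change lowers the number rather than raising it. The entering group keeps the sulfur, the aromatic ring of carbon only, the counts of hydrogen-bond donors and acceptors and the absence of net charge, and no measurement at hand explains the size of the step.

The extra carbon and the iodine arrive together, so the compounds shown leave open how much of the step belongs to each; the same longer chain ending in a plain phenyl ring, or carrying bromine or a methoxy group in place of iodine, would separate the two. Also open, going by these compounds, is whether an amine or an ether oxygen in place of the sulfur would serve in the same way.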